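Fluoro for methoxy on the core of compound 1

The source may report more compounds than this note shows. Statements on the series, on what has been measured and on what is new or still open speak of the compounds shown alone.

Measured so far in a functional assay on MDA-MB-231 cells (Homo sapiens) for cytotoxicity, read by MTT assay, with a stated time of 48 h, in the presence of a further agent that is not named here; on this read-out lower numbers stand for stronger inhibition and higher numbers for weaker inhibition:
- compound 1 `COc1ccc2[nH]cc(-c3nc(C(=O)Nc4cc(OC)c(OC)c(OC)c4)cs3)c2c1`: > 100000 nM (a limit)
- compound 2 `COc1ccc(NC(=O)c2csc(-c3c[nH]c4ccc(F)cc34)n2)cc1`: > 100000 nM (a limit)

Compound 1 stands only at a limit of > 100000 nM in this assay and offers no number to step from. Compound 2 also gives only a limit of > 100000 nM here. Compound 3 `COc1cc(NC(=O)c2csc(-c3c[nH]c4ccc(F)cc34)n2)cc(OC)c1OC` carries fluoro in place of methoxy on an aromatic carbon of the core of compound 1. Among the measured compounds shown here, no change beyond the scatter is expected in this assay because of the limit of > 100000 nM in this assay, at which 2 of the 2 values shown sit, across the series so far. The estimated step of a number no higher from compound 1 to compound 3 (the limit leaves the size open) is expected to stay within that scatter. Compound 3 is estimated at 100000 nM with an expected range of 30000 nM to 300000 nM in this read-out.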

Compound 3, half-maximal inhibitory concentration: > 100000 nM
Compound 3 ended at the assay's limit (the forecaster's own chance of this, stated with the estimate: 80%); the middle value sits exactly at the limit.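

Compound 1 and compound 3 both sit at a limit of the assay, so no step between them can be read: the limit of > 100000 nM in this assay, at which 3 of the 3 values shown sit.

The compounds shown leave open whether fluoro in place of methoxy on an aromatic carbon changes the read-out in this assay at all.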